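A few compounds are considered here, and "the series" means these few. Any claim that something is new, unique, unknown or untested is made for them only; others in the source may bear on it.

Values from a functional assay on HepG2 cells (Homo sapiens) for antiproliferative activity, read by fluorescence and resazurin assay, with a stated time of 48 h (a higher number here means a weaker inhibitor, a lower number a stronger inhibitor), follow
- Compound 1 `Cc1noc(NS(=O)(=O)c2ccc(NC(=O)c3cc4ccc(O)cc4oc3=O)cc2)c1C` gives 38800 nM
- Compound 2 `O=C(N/N=C/c1cccnc1)c1cc2ccc(O)cc2oc1=O` gives 18400 nM
- Compound 3 `Cc1noc(NS(=O)(=O)c2ccc(NC(=O)c3cc4ccccc4oc3=O)cc2)c1C` gives 24000 nM

Compound 3 (24000 nM) lies within the usual scatter of both compound 2 and compound 1, so these numbers do not separate it from either. Compound 4 `Cc1noc(NS(=O)(=O)c2ccc(NC(=O)c3cc4cc([N+](=O)[O-])ccc4oc3=O)cc2)c1C` keeps the structure of compound 3 with one change: nitro in place of hydrogen on an aromatic carbon of a six-membered aromatic ring of carbon only, part of a fused or bridged system of two rings.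

Among the measured compounds shown here, no measured compound carries nitro. For the measured compounds named here, the one measured step that bears on this is a 1.6-fold lower number from compound 1 to compound 3 (0.21 log units; within the scatter) with hydrogen in place of hydroxy on an aromatic carbon, and it is a different swap that stays within the scatter. In this assay a step beyond the scatter is therefore not expected, and no direction can be named with confidence. The expected change is a 1.2-fold lower number from compound 3 to compound 4 (0.08 log units; within the scatter) and it would be hard to tell from noise. For compound 4 the estimated value is 20000 nM with an expected range from 7000 nM to 55000 nM in this estimate.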

Compound 4, half-maximal inhibitory concentration: 15000 nM
Compound 4: the middle estimate sits 1.3-fold (0.12 log units) above what was measured, within the range that was stated.
By their numbers in this assay, from the lowest: compounds 4, 2, 3 and 1 (each within the scatter of the next, the first and the last beyond it).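

In this assay nitro in place of hydrogen on the aromatic carbon gives a 1.6-fold lower number from compound 3 to compound 4 (0.20 log units; within the scatter) and this step lies within the usual scatter. Among the compounds shown here, the position on the six-membered carbon ring therefore accepts a group of three heavy atoms, with two hydrogen-bond acceptors and no net charge, without a change that can be told from noise; the earlier compounds, with only hydrogen or hydroxy on that ring, could not show this. Nothing measured here explains the result.

Going by these compounds, whether an amine or a carboxylic acid on this same carbon would give a step beyond the scatter remains open. On these data alone, it is also open whether nitro would behave in the same way on the core of compound 2.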